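Methoxy for Methyl Above a Solubility Floor

The source may hold more compounds than are shown below. What is called first, only, known or untested is meant among the compounds shown, and "the series" means these compounds.

Compound 1, `Cc1cccc2c(NCc3ccco3)nc(NC(C)C)nc12`, gives <= 20000 nM in a physicochemical assay for solubility, at pH 7.4 (on this read-out higher numbers stand for higher solubility and lower numbers for lower solubility), a limit of the measurement.
Compound 2, `Cc1ccc2nc(NC(C)C)nc(NCc3ccco3)c2c1`, gives <= 20000 nM in this assay, also a limit.
Compound 3, `COc1cccc2c(NCc3ccco3)nc(NC(C)C)nc12`, gives <= 20000 nM in this assay, again a limit.

None of the three measured values is a number; each is a limit: the limit of <= 20000 nM in this assay, at which 3 of the 3 values shown sit. Compound 1 and compound 3 differ in one place: methoxy in place of methyl on an aromatic carbon. The step between them, a step that the two limits leave unreadable from compound 1 to compound 3, lies between two limits and cannot be read. Compound 2 has the same atoms as compound 1, joined differently; the difference between the two cores is not broken down here.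

Compound 4, `COc1ccc2nc(NC(C)C)nc(NCc3ccco3)c2c1`, has not yet been measured in this assay. It differs from compound 2 by the same kind of change: methoxy in place of methyl on an aromatic carbon. The surroundings differ: in compound 3 the methoxy stands ortho to a fused ring and meta to a fused ring, while in compound 4 it stands meta to a fused ring and para to a fused ring. Among the compounds with values here, the one measured instance of this change, a step that the two limits leave unreadable from compound 1 to compound 3, offers no size to carry across.

The step from compound 2 to compound 4 is expected to be a step that the limit leaves unreadable from compound 2 to compound 4. That expectation rests on compound 2, whose measurement in this assay is <= 20000 nM, a limit. Compound 4 is accordingly estimated at 12000 nM in this assay, with a range from 3000 nM to 20000 nM.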

Compound 4, solubility: >= 30000 nM
Compound 4: only a limit was reported; the forecaster's own chance of this, stated with the estimate: 85%; middle value at least 2.5-fold (0.39 log units) from the limit.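

In this assay putting methoxy in place of methyl on an aromatic carbon gives an at least 1.5-fold higher number from compound 2 to compound 4 (0.17 log units; that floor lies within the scatter) and that figure is only a floor, set by two limits of the measurement, so the real step could be larger, yet the floor itself does not clear the usual scatter. The same change on the core of compound 1 cannot be read, as both of its ends are limits too, which leaves no size on one core to set against a size on the other, so the result shows neither that the change carries across the two cores nor that it behaves differently on them. Compound 4 is the only one of the compounds shown that sits at the upper limit, while the other three share a lower one: the limit of <= 20000 nM in this assay, at which 3 of the 4 values shown sit.

Still open, as far as these compounds go, is how large the methoxy step really is on either core, which would take real numbers in place of limits at both ends. Also open, from the compounds shown here alone, is whether ethoxy, an amine or a carboxylic acid on the same aromatic carbon would give a value that can be read in this assay and whether any such change would carry from one core to the other.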